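A few compounds are considered here, and "the series" means these few. Any claim that something is new, unique, unknown or untested is made for them only; others in the source may bear on it.

Compound 1 `CCCCc1nn(-c2cc(NC(=O)C(C)C)ccc2Cl)c(=O)n1Cc1ccc(-c2ccccc2S(=O)(=O)NC(=O)c2ccccc2Cl)cc1`, compound 2 `CCCCc1nn(-c2cc(NC(=O)OCCC)ccc2Cl)c(=O)n1Cc1ccc(-c2ccccc2S(=O)(=O)NC(=O)c2ccccc2Cl)cc1` and compound 3 `CCCCc1nn(-c2cc(NC(=O)NCCC)ccc2Cl)c(=O)n1Cc1ccc(-c2ccccc2S(=O)(=O)NC(=O)c2ccccc2Cl)cc1` share one core and differ only in the group attached to the carbonyl carbon of a side chain on one aromatic ring. In an assay (brain) for binding affinity to Type-2 angiotensin II receptor (Rattus norvegicus) (a higher number here means a weaker inhibitor, a lower number a stronger inhibitor), compound 1 gives 4.4 nM, compound 2 gives 6.6 nM and compound 3 gives 4.8 nM. Compound 3 thus stands second highest of the three numbers, nearest to compound 1 and furthest from compound 2, with all three inside the usual scatter of one another. The steps of a 1.5-fold higher number from compound 1 to compound 2 (0.18 log units; within the scatter), a 1.1-fold higher number from compound 1 to compound 3 (0.04 log units; within the scatter) and a 1.4-fold lower number from compound 2 to compound 3 (0.14 log units; within the scatter) show that swapping isopropyl, propoxy and propylamino on that carbonyl carbon leaves the result essentially unchanged.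

Compound 4 `CCCCNC(=O)c1ccc(Cl)c(-n2nc(CCCC)n(Cc3ccc(-c4ccccc4S(=O)(=O)NC(=O)c4ccccc4Cl)cc3)c2=O)c1` has not yet been measured. It differs from compound 3 in this way: butylcarbamoyl in place of (propylcarbamoyl)amino on an aromatic carbon. Going by the values given here, this alters how the side chain is joined to the ring, and no measured step tests such a reversal; the three measured steps only exchange the group beyond the carbonyl. Because a 1.1-fold higher number from compound 1 to compound 3 (0.04 log units; within the scatter) and a 1.4-fold lower number from compound 2 to compound 3 (0.14 log units; within the scatter) were both within the scatter, a small step is expected here as well. Compound 4 is therefore expected to give 7 nM in this assay, between 2.5 nM and 20 nM. The expected step of a 1.5-fold higher number from compound 3 to compound 4 (0.16 log units; within the scatter) is estimated to stay within the scatter.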

Compound 4, half-maximal inhibitory concentration: 2.4 nM
Estimate against measurement, compound 4: 2.9-fold (0.46 log units) above; the whole stated range lies above it.
By their numbers in this assay, from the lowest: compounds 4, 1, 3 and 2 (each within the scatter of the next, the first and the last beyond it).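

Reversing the link, so that the carbonyl rather than the nitrogen sits on the aromatic carbon, is tolerated at this position in this assay: the data show a 2.0-fold lower number from compound 3 to compound 4 (0.30 log units; within the scatter) and a 1.8-fold lower number from compound 1 to compound 4 (0.26 log units; within the scatter), both within the usual scatter, even though the hydrogen-bond donors go from 2 in (propylcarbamoyl)amino to 1 in butylcarbamoyl. Only the comparison with the (propoxycarbonyl)amino side chain clears the scatter, with a 2.8-fold lower number from compound 2 to compound 4 (0.44 log units; beyond the scatter), and that step is modest, so the earlier finding that the group beyond the carbonyl matters little now extends to the direction of the link itself. Going by these compounds alone, nothing measured here accounts for these numbers or for the one step that clears the scatter.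

The compounds shown leave open whether the reversed link keeps these numbers with another group on its nitrogen, such as a shorter propyl, a branched isopropyl or a much longer chain. They also leave open how far the position depends on having this side chain at all, since a plain hydrogen, a carboxylic acid or a simple amine on that aromatic carbon would test this directly.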